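A Methyl Added on the Amine Side Chain

The compounds below may be only part of what the source reports. "The series", "measured", "known", "first", "only" and "open" are said of these compounds alone.

Measured so far:
Compound 1 `COc1cc(/C=C/C(=O)/C=C(/C=C/c2ccc(OC(C)=O)c(OC)c2)NC2CCCCC2)ccc1OC(C)=O` gives 101% in a functional assay on EA.hy 926 cells (Homo sapiens), read by fluorescence, tested at 1 uM; a higher number here means a stronger effect of the compound at the concentration tested, a lower number a weaker effect.
Compound 2 `CCCNC(=C\C(=O)/C=C/c1ccc(O)c(OC)c1)/C=C/c1ccc(O)c(OC)c1` gives 78% in this assay.

Of the two measured compounds, compound 2 stands lowest in this assay; compound 1 lies higher by a gap beyond the usual scatter. Compound 3 `CCC(C)NC(=C\C(=O)/C=C/c1ccc(O)c(OC)c1)/C=C/c1ccc(O)c(OC)c1` has not been measured. It differs from compound 2 by methyl in place of hydrogen on a saturated chain carbon bound to an amine nitrogen and a saturated chain carbon. Among the compounds with values here, no measured pair shows a comparable change, so a small step is expected no change at the digits printed from compound 2 to compound 3 (within the scatter), none beyond the scatter in either direction. Compound 3 is therefore expected to give about 78%, within a range from 62% to 94%.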

Compound 3, a percentage reported as activity, at one concentration (the size of the read-out at that concentration, not a potency): 85%
Compound 3: middle estimate off by 7 percentage points, on the low side, within the range that was stated.
By their numbers in this assay, from the lowest: compounds 2 and 3 (each within the scatter of the next); then compound 1.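

The change from propyl to sec-butyl gives a number 7 percentage points higher from compound 2 to compound 3 (within the scatter) in this assay. This saturated chain carbon on the amine side chain therefore takes an added methyl, and branching there, without a shift that can be told from the scatter. No evidence at hand gives a reason for this result.

On these data alone, whether a longer chain, a tert-butyl group or a hydroxyl on this carbon would also leave the read-out within the scatter stays open. Compound 1 differs from both compounds in more than one place, so the part played by its cyclohexyl group cannot be read separately.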